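Another Benzyl Group on a Series Stuck at Assay Limits

The source may report more compounds than this note shows. Statements on the series, on what has been measured and on what is new or still open speak of the compounds shown alone.

compound 1 `COc1cc(N)c(Cl)cc1NC(=O)C1CCN(CC2CCCC2)CC1`: > 10 mg/kg
compound 2 `COc1cc(N)c(Cl)cc1NC(=O)C1CCN(C2CCCC2)CC1`: > 10 mg/kg
compound 3 `COc1cc(N)c(Cl)cc1NC(=O)C1CCN(Cc2ccc(OCc3ccccc3)cc2)CC1`: > 4 mg/kg

In a functional assay on the whole organism for antagonist activity, with Mus musculus as the target (a higher number here means that more compound is needed for the effect, a lower number that less compound is needed), compound 1 gives only a limit, > 10 mg/kg. Compound 2 likewise gives only a limit, > 10 mg/kg. Compound 3 also gives only a limit, > 4 mg/kg. Compound 2 thus stands at the limit of > 10 mg/kg in this assay, at which 2 of the 3 values shown sit, and the step that the two limits leave unreadable from compound 1 to compound 2 cannot be read. Compound 4 `COc1cc(N)c(Cl)cc1NC(=O)C1CCN(Cc2cccc(Cl)c2)CC1` carries 3-chlorobenzyl in place of cyclopentyl on an amine nitrogen in a ring. Among the measured compounds shown here, no readable measured step bears on this change; the one step available is unreadable, and the other compound bearing a benzyl-type group, compound 3, sits at the limit of > 4 mg/kg in this assay, at which 1 of the 3 values shown sits. No step beyond the scatter is therefore expected. Compound 4 is expected to give about 15 mg/kg, within 3 mg/kg to 60 mg/kg, most likely as another limit. The estimated step is a step that the limit leaves unreadable from compound 2 to compound 4.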

Compound 4, dose for half-maximal effect: > 4 mg/kg
Compound 4: no number, only a limit; the forecaster's own chance of this, stated with the estimate: 70%; the middle value does not contradict the limit.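

Compound 4 gives only a limit in this assay, > 4 mg/kg, so its steps from compound 1 and compound 2 cannot be read. The compounds shown leave open what dose any of these groups on the amine nitrogen actually requires.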